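The compounds below may be only part of what the source reports. "The series", "measured", "known", "first", "only" and "open" are said of these compounds alone.

Compound 1 `O/N=C(/CSc1nnc(-c2ccccc2)n1-c1ccccc1)c1ccccc1` and compound 2 `CCn1c(SC/C(=N/O)c2ccccc2)nnc1-c1ccc(OC)cc1` share a core and differ in two places. In a functional assay on the whole organism (strain albino) for inhibition, with Rattus norvegicus as the target, read by paw edema, with a stated time of 4 h, at a dose of 0.28 mmol/kg by the oral route (on this read-out lower numbers stand for less inhibition and higher numbers for more inhibition at the one dose given (going by the name of the read-out)), compound 1 gives 79%. In this assay compound 2 gives 78%, a number sitting within the usual scatter of the value of compound 1, so the two cannot be told apart. Compound 3 `CCn1c(SC/C(=N/O)c2ccccc2)nnc1-c1ccccc1` differs from compound 2 by hydrogen in place of methoxy on an aromatic carbon. Among the compounds with values here, no step between measured compounds is available, yet compound 1 already carries phenyl and gives 79%, so the step of a number 1 percentage points lower from compound 2 to compound 3 (within the scatter) is expected to stay within the scatter. Compound 3 is estimated at 77%, between 65% and 87%.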

Compound 3, a percentage reported as inhibition, in the whole organism at one dose (the size of the read-out at that dose, not a potency): 73%
Beside the measured number, compound 3's estimate is 4 percentage points above it; measured number inside the range.
By their numbers in this assay, from the lowest: compounds 3, 2 and 1 (each within the scatter of the next).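

In this assay hydrogen in place of methoxy gives a number 5 percentage points lower from compound 2 to compound 3 (within the scatter) and so shows that, on this aromatic carbon, the two groups cannot be told apart. Ethyl in place of phenyl on the aromatic nitrogen gives a number 6 percentage points lower from compound 1 to compound 3 (within the scatter) and likewise cannot be read as a real change. Nothing measured here gives a reason for either result.

On these data alone, whether an amine or a carboxylic acid on that aromatic carbon, or a longer chain on the aromatic nitrogen, would give a step beyond the scatter stays open.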